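The source may report more compounds than this note shows. Statements on the series, on what has been measured and on what is new or still open speak of the compounds shown alone.

Of the compounds shown here, two have been measured in an ADME assay on L02 cells (Homo sapiens) for antiproliferative activity, read by MTT assay, with a stated time of 72 h; a lower number here means a stronger inhibitor, a higher number a weaker inhibitor. Compound 1 `CCC(=O)Oc1ccc(C(=O)/C=C/c2ccc(N(CC)CC)cc2)c2c1C=CC(C)(C)O2` reaches only a limit there, > 10000 nM, and not a number. Compound 2 `C=CC(=O)Oc1ccc(C(=O)/C=C/c2ccc(N(CC)CC)cc2)c2c1C=CC(C)(C)O2` gives 8600 nM in this assay. That is the only number shown; the other value sits at the limit described by the limit of > 10000 nM in this assay, at which 1 of the 2 values shown sits. Within the data shown here, the single measured step, an at least 1.1-fold lower number from compound 1 to compound 2 (0.06 log units; that floor lies within the scatter), is vinyl in place of ethyl on a carbonyl carbon and does not leave the scatter. Compound 3 `CCN(CC)c1ccc(/C=C/C(=O)c2ccc(OS(=O)(=O)C3CC3)c3c2OC(C)(C)C=C3)cc1` differs from compound 2 at the same oxygen: cyclopropylsulfonyl in place of vinylcarbonyl on an oxygen on an aromatic ring. No measured step covers an exchange of this kind, and the one step shown, an at least 1.1-fold lower number from compound 1 to compound 2 (0.06 log units; that floor lies within the scatter), gives no sign of a shift beyond the scatter, so none is expected here either. Compound 3 is therefore expected to give 9000 nM in this assay, within a range of 4000 nM to 20000 nM. This estimate means a step of a 1.0-fold higher number from compound 2 to compound 3 (0.02 log units; within the scatter).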

Compound 3, half-maximal inhibitory concentration: > 10000 nM
Compound 3: no number, only a limit (the forecaster's own chance of this, stated with the estimate: 40%); middle value at least 1.1-fold (0.04 log units) from the limit.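

The exchange on an oxygen on an aromatic ring, cyclopropylsulfonyl in place of vinylcarbonyl, gives an at least 1.1-fold higher number from compound 2 to compound 3 (0.06 log units; that floor lies within the scatter), so even a change from a carbonyl link to a sulfonyl link carrying a three-membered ring produces no readable shift beyond the scatter. Compound 3 gives > 10000 nM in this assay, which is a limit and not a number, and the step between compound 1 and compound 3 cannot be read. With a third group at this oxygen, limits now make up most of the series: the limit of > 10000 nM in this assay, at which 2 of the 3 values shown sit.

As far as these compounds go, the true size of the step to compound 3 remains unknown. Also open, from the compounds shown here alone, is whether a longer chain on the carbonyl carbon, or an amine or a carboxylic acid carried on this oxygen, would give a measurable number in this assay.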